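The compounds below may be only part of what the source reports. "The series", "measured", "known", "first", "only" and "open" are said of these compounds alone.

Notes on the series. Compound 3 `CSc1ccc(/C=C(/SCc2ccc(C)cc2)C(=O)c2ccc(Cl)cc2)cc1` gives the highest of the two numbers in a functional assay on DU-145 cells (Homo sapiens) for inhibition, read by trypan blue exclusion, with a stated time of 96 h (on this read-out higher numbers stand for weaker inhibition of growth and lower numbers for stronger inhibition of growth), at 25000 nM. Compound 2 `Cc1ccc(CS/C(=C/c2ccc(O)cc2)C(=O)c2ccc(Cl)cc2)cc1` gives 10000 nM, so that a 2.5-fold higher number from compound 2 to compound 3 (0.40 log units; beyond the scatter). Compound 1 `Cc1ccc(CS/C(=C/c2ccc(N(C)C)cc2)C(=O)c2ccc(Cl)cc2)cc1` gives only a limit of the assay, not a number: > 100000 nM (the limit of > 100000 nM in this assay, at which 1 of the 3 values shown sits). From this limit the steps are an at least 10-fold lower number from compound 1 to compound 2 (1.00 log units; beyond the scatter) and an at least 4.0-fold lower number from compound 1 to compound 3 (0.60 log units; beyond the scatter).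

Compound 4 `Cc1ccc(CS/C(=C/c2ccc(Cl)cc2)C(=O)c2ccc(Cl)cc2)cc1` is the next variation at this site: chloro in place of methylsulfanyl on an aromatic carbon. Within the data shown here, no measured step carries chloro; the three measured groups differ from one another by steps of modest size, and two of those rest on a limit. A step of modest size is therefore expected, a 1.7-fold lower number from compound 3 to compound 4 (0.22 log units; within the scatter), with the direction open. Compound 4 is estimated at 15000 nM, within 4000 nM to 60000 nM.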

Compound 4, concentration for 50% growth inhibition: 10000 nM
The estimate for compound 4 lay 1.5-fold (0.18 log units) above the measured number, and the stated range covers the measured number.
By their numbers in this assay, from the lowest: compounds 2 and 4 (each within the scatter of the next); then compound 3. At a limit, above all of these: compound 1.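

In this assay, chloro gives a 2.5-fold lower number from compound 3 to compound 4 (0.40 log units; beyond the scatter), and against hydroxy it gives no change at the digits printed from compound 2 to compound 4 (within the scatter), so two quite different groups at this position now read alike, while methylsulfanyl sits apart from both. The step against dimethylamino is an at least 10-fold lower number from compound 1 to compound 4 (1.00 log units; beyond the scatter), which extends the gap already seen for the other groups. Compound 1 stands at a limit of the assay, not a number: the limit of > 100000 nM in this assay, at which 1 of the 4 values shown sits.

Open, as far as these compounds go, is how far the dimethylamino step really reaches. Also open, from the compounds shown here alone, is whether a methoxy group, a primary amine or a carboxylic acid at this position would read with chloro and hydroxy or with dimethylamino.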